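Phenyl in Place of Nitrile on the Pendant Ring

The source may hold more compounds than are shown below. What is called first, only, known or untested is meant among the compounds shown, and "the series" means these compounds.

Compound 1, `CC(C)c1cc(C(C)(C)C)cc(-c2cccc(C#N)c2)c1CO`: > 50000 nM (a limit of the assay, not a number)
Compound 2, `CC(C)c1cc(C(C)(C)C)cc(-c2ccc(-c3ccccc3)cc2)c1CO`: 680 nM
Compound 3, `Cc1ccc(-c2cc(C(C)(C)C)cc(C(C)C)c2CO)cc1`: 300 nM

All three share one core and differ only in the substituent carried on the pendant aromatic ring. Going by these compounds, in a functional assay on RKE cells for antagonist activity at Vasoactive intestinal polypeptide receptor 1 (Rattus norvegicus), read by HTRF and cAMP accumulation, with stated times of 10 min and 30 min (on this read-out lower numbers stand for stronger inhibition and higher numbers for weaker inhibition), compound 1 gives only a limit, > 50000 nM, so its true potency is unknown. That it sits at the limit of > 50000 nM in this assay, at which 1 of the 3 values shown sits, is the one fact known of it. Compound 2 and compound 3 are both measured: the step of a 2.3-fold lower number from compound 2 to compound 3 (0.36 log units; beyond the scatter) shows that exchanging phenyl for methyl on that ring changes the number only modestly, so the two aromatic and alkyl substituents behave alike there.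

Compound 4, `CC(C)c1cc(C(C)(C)C)cc(-c2cccc(-c3ccccc3)c2)c1CO`, has not been measured. Its change from compound 1 is phenyl in place of cyano on an aromatic carbon, the phenyl standing meta to a large group. Among the compounds with values here, no measured step covers exactly this position, but compound 2 shows that a phenyl on the pendant ring is compatible with activity, and compound 1 shows that the nitrile alone leaves the assay at its limit. Compound 4 is therefore expected to leave the limit and give a measurable number, with the step of an at least 20-fold lower number from compound 1 to compound 4 (1.30 log units; beyond the scatter) expected to be large. The estimate for compound 4 is 2500 nM, within a range from 400 nM to 20000 nM.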

Compound 4, half-maximal inhibitory concentration: 210 nM
For compound 4 the middle estimate is 12-fold (1.08 log units) above the measured one; the measured number lies below the stated range.
By their numbers in this assay, from the lowest: compounds 4 and 3 (each within the scatter of the next); then compound 2. At a limit, above all of these: compound 1.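

In this assay the exchange of cyano for phenyl on an aromatic carbon, meta to a large group, gives an at least 230-fold lower number from compound 1 to compound 4 (2.37 log units; beyond the scatter). Within the data shown here, this is the first direct reading at this position, and it shows that a phenyl placed there is compatible with activity, whereas the earlier phenyl-bearing compound 2 carried that ring at a different place and so could not speak for this one. Compound 1 remains a limit of the assay, so the step marks only the least size of the change and not its true size: the limit of > 50000 nM in this assay, at which 1 of the 4 values shown sits.

The compounds shown leave open whether a phenyl is required at this position, or whether a methyl, an amine or a carboxylic acid placed on the same aromatic carbon would also give a measurable number. They also leave open whether a phenyl bearing a further group, such as a methoxy or a chlorine, or a saturated ring such as cyclohexyl, would keep the activity seen with compound 4.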